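Swapping acetyl for dimethylamino on a growth inhibitor

The source may report more compounds than this note shows. Statements on the series, on what has been measured and on what is new or still open speak of the compounds shown alone.

Compound 1 `COc1cc(C)cc(-c2c(-c3ccnc(-c4ccc(C(C)=O)cc4)c3)cnn2CC#N)c1` is one of three compounds tested in a functional assay on HCT-116 cells (Homo sapiens) for inhibition, read by sulforhodamine B assay, with a stated time of 48 h; a lower number here means a stronger inhibitor of growth, a higher number a weaker inhibitor of growth; in this assay compound 1 gives 1700 nM, which is the second highest of the three numbers. Its closest neighbour is compound 2 `Cc1cc(O)cc(-c2nn(CC#N)cc2-c2ccnc(-c3ccc(Oc4ccccc4)cc3)c2)c1`, which in this assay gives 1560 nM, and the furthest is compound 3 `Cc1cc(O)cc(-c2nn(CC#N)cc2-c2ccnc(-c3ccc(N(C)C)cc3)c2)c1`, which gives 2710 nM; both gaps to compound 1 fall within the scatter. Among the measured compounds shown here, the one comparison between measured compounds that changes a single place is a 1.7-fold higher number from compound 2 to compound 3 (0.24 log units; within the scatter), a swap of dimethylamino for phenoxy.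

Compound 4 `COc1cc(C)cc(-c2c(-c3ccnc(-c4ccc(N(C)C)cc4)c3)cnn2CC#N)c1` differs from compound 1 in one place: dimethylamino in place of acetyl on an aromatic carbon. For the measured compounds named here, no measured pair exchanges acetyl for dimethylamino directly, so the nearest guide is the step from compound 2 to compound 3, which also ends in dimethylamino and stayed within the scatter. The step is therefore expected to be small, at most a slightly higher number: a 1.3-fold higher number from compound 1 to compound 4 (0.11 log units; within the scatter). Compound 4 is thus estimated at 2200 nM, with a likely range from 1000 nM to 5000 nM.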

Compound 4, concentration for 50% growth inhibition: 50.1 nM
For compound 4 the middle estimate is 44-fold (1.64 log units) above the measured one, and the stated range ends above it.
By their numbers in this assay, from the lowest: compound 4; then compounds 2, 1 and 3 (each within the scatter of the next).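

In this assay, the group para to a large group on the aromatic ring turns out to matter a great deal: the change gives a 34-fold lower number from compound 1 to compound 4 (1.53 log units; beyond the scatter) and is not a small adjustment. Among the compounds shown here, the only earlier single-place step, a 1.7-fold higher number from compound 2 to compound 3 (0.24 log units; within the scatter), also ended in dimethylamino yet stayed within the scatter, so dimethylamino at this place does not bring a large step in every setting. The counts do not separate the two groups, since acetyl and dimethylamino match in heavy atoms and hydrogen-bond acceptors, and nothing measured here accounts for the step.

From the compounds shown here alone, whether diethylamino, a primary amine or a carboxylic acid at this place would give a number near that of compound 4 remains open. Also open, going by these compounds, is how far the step depends on the rest of the molecule.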